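Hydroxyl placement on the aryl ring: compound 3 to compound 4

The compounds below may be only part of what the source reports. "The series", "measured", "known", "first", "only" and "open" are said of these compounds alone.

Measured compounds:
Compound 1 `Oc1cccc(-c2cc(-c3ccc(Cl)cc3)nc(-c3ccco3)c2)c1` — 10200 nM
Compound 2 `Oc1cccc(-c2cc(-c3ccncc3)nc(-c3ccccc3Cl)c2)c1` — "not determined" (no result reported)
Compound 3 `Oc1ccc(-c2cc(-c3ccsc3)nc(-c3cccc(Cl)c3)c2)cc1` — 5760 nM

The read-out throughout is a functional assay on HCT-15 cells (Homo sapiens) for cytotoxicity, read by CCK-8 assay and cell counting, with a stated time of 2 days; a lower number here means a stronger inhibitor, a higher number a weaker inhibitor. Compound 3 holds the lowest of the two numbers obtained; its nearest neighbour is compound 1, which gives 10200 nM, and that gap stays within the scatter, so no order between the two can be read. For compound 2 no number was obtained in this assay.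

Compound 4 `Oc1cccc(-c2cc(-c3ccsc3)nc(-c3cccc(Cl)c3)c2)c1` has the same atoms as compound 3, joined differently: 3-hydroxyphenyl in place of 4-hydroxyphenyl on an aromatic carbon. Compound 1 also carries a 3-hydroxyphenyl group, but it differs from compound 3 in further places, so no single-change comparison is available from the measured set. The expectation is therefore a step of no more than the scatter in this assay, if anything toward a higher number. Compound 4 is estimated at 7500 nM, with a range of 2500 nM to 22000 nM. That estimate means an expected step of a 1.3-fold higher number from compound 3 to compound 4 (0.11 log units; within the scatter).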

Compound 4, half-maximal inhibitory concentration: 2510 nM
For compound 4 the middle estimate is 3.0-fold (0.48 log units) above the measured one, within the range that was stated.
By their numbers in this assay, from the lowest: compound 4; then compounds 3 and 1 (each within the scatter of the next).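

In this assay the hydroxyl shift from 4-hydroxyphenyl to 3-hydroxyphenyl gives a 2.3-fold lower number from compound 3 to compound 4 (0.36 log units; beyond the scatter) with the atoms unchanged, so this position on the shared core responds to where the hydroxyl sits, if only modestly. The earlier compounds shown here offered no single-change comparison, and this pair alone isolates the placement of the hydroxyl, with the thiophen-3-yl and 3-chlorophenyl groups held constant. No measurement at hand accounts for the step.

Still open, from the compounds shown here alone, is whether the hydroxyl is needed at all: an amine or a carboxylic acid in its place on the same phenyl ring would test that. Also open, going by these compounds, is whether the same preference for 3-hydroxyphenyl holds with other groups on the core, such as those of compound 1.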